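Swapping a methyl for trifluoromethyl on a pyrazolopyridinone

A few compounds are considered here, and "the series" means these few. Any claim that something is new, unique, unknown or untested is made for them only; others in the source may bear on it.

Of the compounds shown here, three that share one core have been tested in an ADME assay on TZM cells (Homo sapiens) for cytotoxicity, read by MTT assay, with a stated time of 48 h; on this read-out higher numbers stand for lower toxicity in this test and lower numbers for higher toxicity in this test. Compound 1, `Cc1ccc(-n2ncc3c(=O)[nH]c(C)cc32)cc1`, gives 383000 nM, the highest of the three numbers, which means the lowest toxicity in this test. Compound 2, `Cc1cc2c(cnn2-c2ccc(C)c(C)c2)c(=O)[nH]1`, gives 93400 nM, and compound 3, `Cc1cc2c(cnn2-c2cccc(C(F)(F)F)c2)c(=O)[nH]1`, gives 34100 nM.

Compound 4, `Cc1cc2c(cnn2-c2ccc(C(F)(F)F)cc2)c(=O)[nH]1`, has not yet been measured. It differs from compound 1 in one place: trifluoromethyl in place of methyl on an aromatic carbon.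

For the measured compounds named here, only one measured step joins two compounds that differ in a single place, the one from compound 1 to compound 2, where a methyl in place of hydrogen on an aromatic carbon gave a 4.1-fold lower number from compound 1 to compound 2 (0.61 log units; beyond the scatter). Going by the values given here, no step with trifluoromethyl in place of methyl has been measured, so the change in compound 4 is new. Compound 3 carries a trifluoromethyl on the same ring and shows a much lower number than compound 1, which points the same way as the step to compound 2.

Taken together, these numbers suggest that compound 4 is expected to show a lower number than compound 1, a step of about a 7.7-fold lower number from compound 1 to compound 4 (0.88 log units; beyond the scatter) in this assay, well beyond the scatter. The value of compound 4 in this assay is therefore estimated at 50000 nM, with a likely range from 15000 nM to 150000 nM.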

Compound 4, half-maximal cytotoxic concentration: 100000 nM
Beside the measured number, compound 4's estimate is 2.0-fold (0.30 log units) below it; low and high end bracket the measured number.
By their numbers in this assay, from the lowest: compound 3; then compounds 2 and 4 (each within the scatter of the next); then compound 1.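

For the compounds shown here, compound 4 gives the first direct reading of what trifluoromethyl does in place of methyl on an aromatic carbon para to a large group: in this assay, the change brings a 3.8-fold lower number from compound 1 to compound 4 (0.58 log units; beyond the scatter), so the group at this place does affect the outcome. Going by these compounds alone, the size of this step is close to that of the only earlier single-place step, a 4.1-fold lower number from compound 1 to compound 2 (0.61 log units; beyond the scatter), which added a methyl rather than exchanging one group for another, so two different changes to compound 1 have now been seen to lower the number, meaning higher toxicity in this test. Nothing available explains why trifluoromethyl lowers the number here, and the result alone cannot separate the effect of its added fluorine atoms from any other difference between the two groups.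

The compounds shown leave open how far this trend extends at the same place, for instance whether an amine, a carboxylic acid or a longer chain would lower the number further, leave it unchanged or raise it. They also leave open whether a plain hydrogen there would give a number higher or lower than that of compound 1.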